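Fluoro in place of hydrogen in a series at its limit

The source may hold more compounds than are shown below. What is called first, only, known or untested is meant among the compounds shown, and "the series" means these compounds.

compound 1 `CCOC(=O)c1c(-c2cc(F)cc(OC)c2)[nH]c2cc(OC)ccc2c1=O` gives > 21500 nM
compound 2 `CCOC(=O)c1c(-c2cccc(OC)c2)[nH]c2cc(OC)ccc2c1=O` gives > 21500 nM
compound 3 `CCOC(=O)c1c(-c2cccc(OCC(C)C)c2)[nH]c2cc(OC)ccc2c1=O` gives > 21500 nM

The picture in an ADME assay on Raji cells (Homo sapiens) for cytotoxicity, read by luminescence, with a stated time of 72 h (a higher number here means that more compound is needed for the effect, a lower number that less compound is needed), is uniform, and all three entries are limits, not numbers: the limit of > 21500 nM in this assay, at which 3 of the 3 values shown sit. Compound 2 therefore has no number of its own, only the limit > 21500 nM, so no exact starting point is available.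

The next structure is compound 4 `CCOC(=O)c1c(-c2cccc(OC)c2)[nH]c2cc(OC)c(F)cc2c1=O`. Its difference from compound 2 is fluoro in place of hydrogen on an aromatic carbon.

Among the compounds with values here, two measured steps bear on this change. The closer one is a step that the two limits leave unreadable from compound 1 to compound 2, which also exchanges fluoro and hydrogen on an aromatic carbon, though at another place in the structure. The other is a step that the two limits leave unreadable from compound 2 to compound 3, with isopropyl in place of hydrogen on a saturated chain carbon bound to an oxygen on an aromatic ring. Neither step has a readable size. Compound 1 already carries a fluoro and gives > 21500 nM, which is again a limit.

No direction can be drawn from these steps, so compound 4 is expected to remain at the limit of this assay. The estimated size is a number no higher from compound 2 to compound 4 (the limit leaves the size open), and nothing beyond the scatter is expected. Compound 4 is estimated at 21500 nM, with an expected range from 6000 nM to 40000 nM.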

Compound 4, half-maximal effective concentration: > 21500 nM
Compound 4 was reported as a limit (the forecaster's own chance of this, stated with the estimate: 80%); the middle value sits exactly at the limit.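

In this assay compound 4 gives > 21500 nM, which is a limit. Compound 2 is likewise reported only as a limit, so no step can be read between compound 2 and compound 4, and the series stays uniform: the limit of > 21500 nM in this assay, at which 4 of the 4 values shown sit.

The compounds shown leave open how far each lies past the limit, and whether fluoro in place of hydrogen changes the value at all.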